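The compounds below may be only part of what the source reports. "The series", "measured", "known", "first", "only" and "open" are said of these compounds alone.

Compound 1 `COc1cc(/C=C\c2ccc(N(C)C)c([N+](=O)[O-])c2)cc(OC)c1OC` is tested in a functional assay on HeLa cells (Homo sapiens) for inhibition; on this read-out lower numbers stand for stronger inhibition and higher numbers for weaker inhibition. In this assay compound 1 gives only a limit, > 5000 nM. Compound 2 `COc1cc(/C=C\c2ccc(N(C)C)c(N)c2)cc(OC)c1OC` gives 3 nM in this assay. Going by these compounds, the change amino in place of nitro on an aromatic carbon brings an at least 1600-fold lower number from compound 1 to compound 2 (3.22 log units; beyond the scatter), a step whose full size stays open because of the limit of > 5000 nM in this assay, at which 1 of the 3 values shown sits. Compound 3 `COc1cc(/C=C/c2ccc3ccccc3c2)cc([N+](=O)[O-])c1OC` gives 3200 nM in this assay; how its core differs from that of compound 1 is not broken down here. Compound 4 `COc1cc(/C=C/c2ccc3ccccc3c2)cc(N)c1OC` differs from compound 3 by amino in place of nitro on an aromatic carbon, the same kind of change, though here the place is ortho to a methoxy group and meta to a methoxy group rather than ortho to a dimethylamino group. For compound 4 a step of about a 110-fold lower number from compound 3 to compound 4 (2.03 log units; beyond the scatter) is expected, resting on an at least 1600-fold lower number from compound 1 to compound 2 (3.22 log units; beyond the scatter). Compound 4 is estimated at 30 nM, between 3 nM and 300 nM.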

Compound 4, half-maximal inhibitory concentration: 460 nM
Beside the measured number, compound 4's estimate is 15-fold (1.19 log units) below it; the measured number lies above the stated range.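

In this assay, amino in place of nitro again gives a lower number, with a 7.0-fold lower number from compound 3 to compound 4 (0.84 log units; beyond the scatter), so the direction of the change carries over to the second core but its size does not: the same change on two cores in this assay, an at least 1600-fold lower number (3.22 log units; beyond the scatter) from compound 1 to compound 2 and a 7.0-fold lower number (0.84 log units; beyond the scatter) from compound 3 to compound 4, at least 230-fold (2.37 log units) apart, beyond the scatter of two such steps

Compound 1 gives a limit, not a number, so the full size of the earlier step stays unknown: the limit of > 5000 nM in this assay, at which 1 of the 4 values shown sits.

These two pairs show that the size of the step depends on the core, but they do not show which difference between the cores matters, and they give no rule for predicting the step on a third core.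

The compounds shown leave open how a hydroxyl group or an acetamide in the same place would compare with amino and nitro on either core.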